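Amide nitrogen substituent: aryl versus benzyl in a chromone series

The source may report more compounds than this note shows. Statements on the series, on what has been measured and on what is new or still open speak of the compounds shown alone.

The series has a shared core carrying an acrylamide whose nitrogen substituent varies. Compound 1 `COc1ccc2c(=O)c(/C=C/C(=O)NCc3cccc(F)c3)coc2c1` carries a 3-fluorobenzyl group there and gives 26900 nM in a functional assay on A549 cells (Homo sapiens) for inhibition, read by MTT assay, with a stated time of 48 h; a lower number here means a stronger inhibitor, a higher number a weaker inhibitor. Compound 2 `COc1ccc(NC(=O)/C=C/c2coc3cc(OC)ccc3c2=O)cc1` carries a 4-methoxyphenyl group and gives 23000 nM in this assay. Compound 2 has the lower of the two numbers, but the step of a 1.2-fold lower number from compound 1 to compound 2 (0.07 log units; within the scatter) is within the scatter, so the two compounds cannot be separated.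

Compound 3 `COc1ccc(CNC(=O)/C=C/c2coc3cc(OC)ccc3c2=O)cc1` is not yet measured. It differs from compound 2 by 4-methoxybenzyl in place of 4-methoxyphenyl on an amide-type nitrogen. Going by the values given here, the only measured step that bears on this is the one from compound 1 to compound 2, which exchanged a benzyl for an aryl group on the same nitrogen and moved the number by no more than the scatter. Going back to a benzyl group, now carrying the 4-methoxy substituent, is therefore expected to give a step of a 1.1-fold higher number from compound 2 to compound 3 (0.04 log units; within the scatter) in this assay that stays within the scatter, in no particular direction. Compound 3 is expected to give 25000 nM in this assay, with a range from 10000 nM to 60000 nM.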

Compound 3, half-maximal inhibitory concentration: 22500 nM
For compound 3 the middle estimate is 1.1-fold (0.05 log units) above the measured one; low and high end bracket the measured number.
By their numbers in this assay, from the lowest: compounds 3, 2 and 1 (each within the scatter of the next).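

In this assay, 4-methoxybenzyl in place of 4-methoxyphenyl on the amide-type nitrogen gives a 1.0-fold lower number from compound 2 to compound 3 (0.01 log units; within the scatter), so with the 4-methoxy substituent held, the presence of the saturated chain carbon does not separate compound 2 and compound 3. 4-Methoxyphenyl in place of 3-fluorophenyl on that saturated chain carbon gives a 1.2-fold lower number from compound 1 to compound 3 (0.08 log units; within the scatter), which isolates the ring substituent, a change the earlier step from the benzyl to the aryl group could not separate from the loss of the chain carbon, and this change also does not separate the compounds. No measured evidence accounts for these small steps.

From the compounds shown here alone, the three compounds all carry a ring of carbon only on this nitrogen, so it remains open whether an amine or a carboxylic acid on that ring, or a longer chain between the ring and the nitrogen, would give a step beyond the scatter. Going by these compounds, the shared core and the acrylamide stay the same throughout, so how the number responds to changes in those parts also remains open.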